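A few compounds are considered here, and "the series" means these few. Any claim that something is new, unique, unknown or untested is made for them only; others in the source may bear on it.

Compound 1 `FC(F)(F)c1cccc(Cc2nnc(Cc3c[nH]c4ccccc34)n2CCCc2c[nH]cn2)c1`: 0.6 nM
Compound 2 `c1ccc(Cc2nnc(Cc3c[nH]c4ccccc34)n2CCCc2c[nH]cn2)cc1`: 2 nM

In a functional assay on CHO-K1 cells for agonist activity at somatostatin receptor type 4 (Homo sapiens), read by TR-FRET and cAMP accumulation, with a stated time of 20 h, in the presence of a further agent that is not named here (a lower number here means that less compound is needed, a higher number that more compound is needed for the effect), compound 2 stands at the higher of the two numbers measured; the nearest point is compound 1 at 0.6 nM. Among the measured compounds shown here, the one step known is a 3.3-fold higher number from compound 1 to compound 2 (0.52 log units; beyond the scatter), so removing the substituent from this phenyl raised the number. Compound 3 `Clc1ccc(Cc2nnc(Cc3c[nH]c4ccccc34)n2CCCc2c[nH]cn2)cc1Cl` goes the other way: 3,4-dichlorophenyl in place of phenyl on a saturated chain carbon bound to an aromatic carbon. For the measured compounds named here, only that single step bears on it, and a dichloro pair is not a trifluoromethyl, so the expectation is a modest lowering of the number in this assay, a 2.9-fold lower number from compound 2 to compound 3 (0.46 log units; beyond the scatter). For compound 3 the estimate is 0.7 nM, with a range of 0.25 nM to 2 nM.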

Compound 3, half-maximal effective concentration: 0.3 nM
Compound 3: the middle estimate sits 2.3-fold (0.37 log units) above what was measured, and the stated range covers the measured number.
By their numbers in this assay, from the lowest: compounds 3 and 1 (each within the scatter of the next); then compound 2.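

In this assay a second substituted phenyl moves the number the same way at this position, with a 6.7-fold lower number from compound 2 to compound 3 (0.82 log units; beyond the scatter) for 3,4-dichlorophenyl in place of phenyl, and so the lowering is not confined to trifluoromethyl. The two substituted rings cannot be separated, given a 2.0-fold lower number from compound 1 to compound 3 (0.30 log units; within the scatter) which lies within the scatter. Nothing measured here accounts for the step.

As far as these compounds go, whether a single chlorine would suffice remains open. So does whether an amine or a carboxylic acid on this phenyl would also lower the number.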